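This account rests on a few compounds, and the source may have more. Where it says the series, first, only, none or still open, it means among the compounds named here.

Three compounds share one core and differ only in the group attached on an aromatic carbon of a six-membered aromatic ring of carbon only, part of a fused system of two rings. Compound 1 `CCONC(=N)c1ccc2[nH]c(-c3cccc(-c4ccccc4O)c3O)cc2c1` carries an ethoxy group on the amine nitrogen of its amidine, and in an in vivo ADME assay on the whole organism (strain Sprague-Dawley) for pharmacokinetics, with Rattus norvegicus as the target (on this read-out higher numbers stand for higher oral bioavailability and lower numbers for lower oral bioavailability), compound 1 gives 67%. Compound 2 `C=CCO/N=C(/N)c1ccc2[nH]c(-c3cccc(-c4ccccc4O)c3O)cc2c1` reaches 100% in this assay, whereas compound 3 `CC(C)OC(=O)NC(=N)c1ccc2[nH]c(-c3cccc(-c4ccccc4O)c3O)cc2c1` gives 23%. Among the three numbers compound 1 stands second highest: the step of a number 33 percentage points higher from compound 1 to compound 2 (beyond the scatter) lies beyond the scatter, and the step of a number 77 percentage points lower from compound 2 to compound 3 (beyond the scatter) is the widest gap of all.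

Compound 4 `N/C(=N/C(=O)OCC(Cl)(Cl)Cl)c1ccc2[nH]c(-c3cccc(-c4ccccc4O)c3O)cc2c1` has not yet been measured. Going from compound 1 to compound 4 means (a group of 11 heavy atoms (4 carbon, 2 nitrogen, 2 oxygen, 3 chlorine; no ring) in place of a group of 6 heavy atoms (3 carbon, 2 nitrogen, 1 oxygen; no ring), on an aromatic carbon). The closest measured precedent is the change from compound 1 to compound 3, in which the ethoxy group on the amine nitrogen was likewise replaced by an alkoxycarbonyl group, and that step was large and downward, a number 44 percentage points lower from compound 1 to compound 3 (beyond the scatter). Going by the values given here, the group entering compound 4 is again an alkoxycarbonyl, differing from the one in compound 3 in the chlorine it carries, so a downward step of comparable size is expected, a number 42 percentage points lower from compound 1 to compound 4 (beyond the scatter). For compound 4 the expected value in this assay is therefore 25%, with a likely range from 5% to 50%.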

Compound 4, oral bioavailability: 14%
Estimate against measurement, compound 4: 11 percentage points above, within the range that was stated.
By their numbers in this assay, from the lowest: compounds 4 and 3 (each within the scatter of the next); then compound 1; then compound 2.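

In this assay the (2,2,2-trichloroethoxy)carbonyl group of compound 4 gives a number 53 percentage points lower from compound 1 to compound 4 (beyond the scatter) and also a number 86 percentage points lower from compound 2 to compound 4 (beyond the scatter), so a low number is now seen with a second alkoxycarbonyl group and not with the isopropoxycarbonyl of compound 3 alone; among these four compounds, the two with an alkoxycarbonyl group both sit far under the two with ethoxy or allyloxy, and none goes against this. The chlorine-bearing group and the isopropoxycarbonyl group cannot be told apart on this read-out, since the change between them amounts to a number 9 percentage points lower from compound 3 to compound 4 (within the scatter), which means that exchanging one alkoxycarbonyl for the other has no visible effect here. Nothing measured here explains why either group goes with such low numbers.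

Going by these compounds, it remains open whether a plain acyl group such as acetyl, which has no alkoxy oxygen, would fall with compound 3 and compound 4 or with compound 1 and compound 2. A longer chain such as butoxy on the same nitrogen also remains untested among the compounds shown, so how far the high numbers extend is unknown.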